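This account rests on a few compounds, and the source may have more. Where it says the series, first, only, none or still open, it means among the compounds named here.

Measured compounds:
Compound 1 `Cc1cc(-c2ccc(O)cc2)cn2c(CSCCc3ccccc3)cnc12` in an ADME assay on HEL cells (Homo sapiens) for cytotoxicity, with a stated time of 3 days (a higher number here means that more compound is tolerated, a lower number that less compound is tolerated), gives > 50 ug/mL, which is a limit of the assay.
Compound 2 `Cc1cc(-c2cccs2)c2ncc(CSCCc3ccccc3)n2c1` in this assay gives > 50 ug/mL, likewise a limit.

Compound 1 therefore stands at the upper limit rather than at a number; the limit of > 50 ug/mL in this assay, at which 2 of the 2 values shown sit, shows that both values sit at that limit. Compound 3 `Cc1cc(-c2cccc([N+](=O)[O-])c2)cn2c(CSCCc3ccccc3)cnc12` carries 3-nitrophenyl in place of 4-hydroxyphenyl on an aromatic carbon, 3-nitrophenyl in place of 4-hydroxyphenyl on an aromatic carbon. Among the measured compounds shown here, no step between measured compounds exists to gauge this change, so he expects a step from compound 1 to compound 3 of a number no higher from compound 1 to compound 3 (the limit leaves the size open), that is, none beyond the scatter. Compound 3 is accordingly estimated at 50 ug/mL, with a range from 25 ug/mL to 100 ug/mL, most likely reported again as a limit.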

Compound 3, half-maximal cytotoxic concentration: 43 ug/mL
Beside the measured number, compound 3's estimate is 1.2-fold (0.07 log units) above it, within the range that was stated.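

Among the compounds shown, compound 3 alone gives a number in this assay, 43 ug/mL, so this position now has a measured value. With 3-nitrophenyl in place of 4-hydroxyphenyl on this aromatic carbon, the result is an at least 1.1-fold lower number from compound 1 to compound 3 (0.06 log units; that floor lies within the scatter), so the change shows no shift beyond the scatter. The true size of the step stays unknown, and the reading for compound 1 is only a limit: the limit of > 50 ug/mL in this assay, at which 2 of the 3 values shown sit.

The compounds shown leave open whether the loss of the hydroxyl or the arrival of the nitro group shapes this value. They also leave open how an amine or a carboxylic acid on this carbon would read in this assay.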